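The compounds below may be only part of what the source reports. "The series", "measured", "known", "first", "only" and "open" are said of these compounds alone.

Measured so far in an ADME assay on cells (Homo sapiens) for cytotoxicity, read by polymerase chain reaction, with a stated time of 3 days; on this read-out higher numbers stand for lower toxicity in this test and lower numbers for higher toxicity in this test:
Compound 1 `Nc1nc(Cl)c(-c2nc3ccccc3o2)c(N[C@@H]2C[C@H](CO)[C@@H](O)[C@H]2O)n1` gives 12000 nM.
Compound 2 `CCOc1ccc2nc(-c3c(Cl)nc(N)nc3N[C@@H]3C[C@H](CO)[C@@H](O)[C@H]3O)sc2c1` gives > 25000 nM, a limit of the assay and not a number.
Compound 3 `Cc1nc(NCC2CC2)nc(N[C@@H]2C[C@H](CO)[C@@H](O)[C@H]2O)c1-c1nc2ccccc2s1` gives 8000 nM.

Compound 3 holds the lower of the two numbers shown, with compound 1 close by and within the usual scatter, so the two cannot be ordered. The result for compound 2 sits at the limit of > 25000 nM in this assay, at which 1 of the 3 values shown sits, and stands apart as a limit.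

Compound 4 `Cc1nc(NCc2cccnc2)nc(N[C@@H]2C[C@H](CO)[C@@H](O)[C@H]2O)c1-c1nc2ccccc2s1` is the next member to be read in this assay. It differs from compound 3 by pyridin-3-yl in place of cyclopropyl on a saturated chain carbon bound to a nitrogen on an aromatic ring. Within the data shown here, no pair among the measured compounds differs in one place, so no measured step of this kind exists; compound 1, compound 2 and compound 3 each differ from one another in several places at once, and the comparisons between them cannot be read as the effect of a single change.

For compound 4 the expectation is a step of a 1.4-fold higher number from compound 3 to compound 4 (0.14 log units; within the scatter), in the direction of a somewhat higher number but not beyond the scatter with any confidence. Compound 4 is therefore expected to give about 11000 nM in this assay, in a range from 4500 nM to 25000 nM, with a real chance that only a limit is returned.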

Compound 4, half-maximal cytotoxic concentration: 5000 nM
Compound 4: middle estimate off by 2.2-fold (0.34 log units), on the high side; the measured number falls inside the stated range.
By their numbers in this assay, from the lowest: compounds 4, 3 and 1 (each within the scatter of the next, the first and the last beyond it). At a limit, above all of these: compound 2.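

At the place on a saturated chain carbon bound to a nitrogen on an aromatic ring, the series now has its first single-change comparison: in this assay, pyridin-3-yl in place of cyclopropyl gives a 1.6-fold lower number from compound 3 to compound 4 (0.20 log units; within the scatter), so the two compounds cannot be ordered. Exchanging a three-membered non-aromatic ring of carbon only for a six-membered aromatic ring with a hetero atom therefore produces no separable shift in this read-out, and this one pair gives no sign that the number responds to the group at this place. No measured property of these compounds bears on this step.

A phenyl ring in the same place would show whether the ring nitrogen of pyridin-3-yl counts for anything apart from the aromatic ring, while a carboxylic acid or a longer alkyl chain would test whether any group here moves the number beyond the scatter. From the compounds shown here alone, whether the same exchange reads the same way on the core of compound 1 or the core of compound 2 also remains open.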